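This account rests on a few compounds, and the source may have more. Where it says the series, first, only, none or still open, it means among the compounds named here.

In an ADME assay on cells (Hepatocyte, Homo sapiens) for metabolic stability (a lower number here means that the compound disappears faster, a higher number that the compound lasts longer), compound 2 `N#Cc1cnc(N2CCC(C(=O)N3N=CC[C@H]3c3cc(F)cc(F)c3)CC2)cn1` gives 3.3 h and compound 1 `O=C(C1CCN(c2ccncn2)CC1)N1N=CC[C@H]1c1ccccc1` gives 3.3 h, so the two stand level, within the scatter. Compound 3 `CC(C)(C)C(=O)N1CCC1c1ccccc1` gives > 2.75 h, which is a limit of the assay and not a number. Compound 4 `N#Cc1nccc(N2CCC(C(=O)N3N=CC[C@H]3c3cc(F)cc(F)c3)CC2)n1` has not yet been measured. It carries 2-cyanopyrimidin-4-yl in place of the 5-cyanopyrazin-2-yl of compound 2, on an amine nitrogen in a ring (2-cyanopyrimidin-4-yl in place of 5-cyanopyrazin-2-yl on an amine nitrogen in a ring). Among the compounds with values here, no measured pair of compounds shows this kind of change, so no step beyond the scatter is expected in this assay, in either direction. The expected step is a 1.1-fold lower number from compound 2 to compound 4 (0.04 log units; within the scatter). The half-life of compound 4 is estimated at 3 h, with an expected range of 1.5 h to 6 h.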

Compound 4, half-life: 2.1 h
For compound 4 the middle estimate is 1.4-fold (0.15 log units) above the measured one; low and high end bracket the measured number.
By their numbers in this assay, from the lowest: compounds 4, 1 and 2 (each within the scatter of the next).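

In this assay, within the data shown here, this is the first pair that differs in one place: on the amine nitrogen in a ring, 2-cyanopyrimidin-4-yl stands in place of 5-cyanopyrazin-2-yl, with a 1.6-fold lower number from compound 2 to compound 4 (0.20 log units; within the scatter). Rearranging the same atoms at this position therefore stays within the scatter. No measurement shown speaks to the reason for this step. As far as these compounds go, it remains open whether a carboxylic acid or an amine in place of the nitrile on this ring would give a step beyond the scatter. From the compounds shown here alone, whether the same change behaves alike on another core also remains open.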